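Ring-nitrogen substituents on the shared core: compound 4

The source may hold more compounds than are shown below. What is called first, only, known or untested is meant among the compounds shown, and "the series" means these compounds.

Within the data shown here, compound 3 `CCCn1c(=O)[nH]c2nc(-c3ccc(S(=O)(=O)N4CCN(c5ccccc5)CC4)cc3)[nH]c2c1=O` stands second highest of the three numbers so far in an assay on CHO cells for displacement of a labelled ligand from adenosine receptor A3 (Homo sapiens), read by scintillation counting, with a stated time of 45 min, tested at 1 uM, in the presence of a further agent that is not named here; a higher number here means more inhibition at the concentration tested (going by the name of the read-out), a lower number less inhibition: compound 2 `CCCn1c(=O)[nH]c2nc(-c3ccc(S(=O)(=O)N4CCN(c5ccccc5Cl)CC4)cc3)[nH]c2c1=O` gives 32%, and compound 3 gives 27%, with a number 5 percentage points lower from compound 2 to compound 3 (within the scatter) between them. Compound 1 `CCCn1c(=O)[nH]c2nc(-c3ccc(S(=O)(=O)N4CCN(C)CC4)cc3)[nH]c2c1=O` gives 7%, and a number 20 percentage points higher from compound 1 to compound 3 (beyond the scatter) separates it from compound 3. Compound 4 `CCCn1c(=O)[nH]c2nc(-c3ccc(S(=O)(=O)N4CCN(C(C)c5ccccc5)CC4)cc3)[nH]c2c1=O` carries 1-phenylethyl in place of phenyl on an amine nitrogen in a ring. Among the measured compounds shown here, no measured step exchanges phenyl for 1-phenylethyl directly. For the measured compounds named here, the steps that bear on it are a number 25 percentage points higher from compound 1 to compound 2 (beyond the scatter) and a number 20 percentage points higher from compound 1 to compound 3 (beyond the scatter), both replacing methyl with an aryl group on the ring nitrogen, while a number 5 percentage points lower from compound 2 to compound 3 (within the scatter) shows that a change on the aryl group itself hardly moves the number. Compound 4 retains an aromatic ring on that nitrogen, and its 1-phenylethyl group is two carbons larger than phenyl. For compound 4 the step of a number 1 percentage points higher from compound 3 to compound 4 (within the scatter) is therefore expected to stay within the scatter, with no clear direction. In this assay compound 4 is estimated at 28%, in the range 12% to 45%.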

Compound 4, a percentage reported as inhibition, at one concentration (the size of the read-out at that concentration, not a potency): 0%
The estimate for compound 4 lay 28 percentage points above the measured number; measured number below the stated range.
By their numbers in this assay, from the lowest: compounds 4 and 1 (each within the scatter of the next); then compounds 3 and 2 (each within the scatter of the next).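

On the amine nitrogen in the ring, in this assay, an aromatic ring in the substituent does not by itself preserve the number: a number 27 percentage points lower from compound 3 to compound 4 (beyond the scatter) and a number 32 percentage points lower from compound 2 to compound 4 (beyond the scatter) are the steps on moving to 1-phenylethyl. The rise seen with phenyl and 2-chlorophenyl over methyl is absent with this group, as a number 7 percentage points lower from compound 1 to compound 4 (within the scatter) leaves 1-phenylethyl level with methyl, so among these four compounds only phenyl and 2-chlorophenyl stand clear of the others. Nothing at hand explains the loss.

Open, on these data alone, is whether benzyl, which is 1-phenylethyl without its methyl, would sit with phenyl or with 1-phenylethyl on this nitrogen. Also open, as far as these compounds go, is how a longer chain such as 2-phenylethyl, or a pyridine ring in place of phenyl, would read in this assay.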